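The source may hold more compounds than are shown below. What is called first, only, known or untested is meant among the compounds shown, and "the series" means these compounds.

In a functional assay on U-251 cells (Homo sapiens) for cytotoxicity (on this read-out higher numbers stand for weaker inhibition of growth and lower numbers for stronger inhibition of growth), three compounds sharing one core have been measured. Compound 1 `COc1ccc(C2=C(c3ccc(SC)cc3)CC3CCCN3C2=O)cc1C` gives 90 nM, compound 3 `COc1ccc(C2=C(c3ccc(SC)cc3)CC3CCCN3C2=O)cc1OC` gives 300 nM, and compound 2 `CSc1ccc(C2=C(c3ccc(C)c(C)c3)C(=O)N3CCCC3C2)cc1` gives 10000 nM, the highest number of the three and so the weakest growth inhibition. Compound 4 `CSc1ccc(C2=C(c3ccc(C)cc3)C(=O)N3CCCC3C2)cc1` differs from compound 2 by one small edit, hydrogen in place of methyl on an aromatic carbon, which turns 3,4-dimethylphenyl into 4-methylphenyl: hydrogen in place of methyl on an aromatic carbon. Among the measured compounds shown here, two measured steps bear on this edit. Methyl in place of methoxy gave a 110-fold higher number from compound 1 to compound 2 (2.05 log units; beyond the scatter), a large step, but it happened on a different ring carbon. Methoxy in place of methyl gave a 3.3-fold higher number from compound 1 to compound 3 (0.52 log units; beyond the scatter), a modest step on the same carbon edited here, which makes it the closer guide. Neither step simply removes a group, so the guidance is indirect. The expected change is small, a 1.3-fold lower number from compound 2 to compound 4 (0.10 log units; within the scatter), which would stay within the scatter. For compound 4 the estimated value is 8000 nM, with an expected range from 2500 nM to 30000 nM.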

Compound 4, concentration for 50% growth inhibition: 400 nM
For compound 4 the middle estimate is 20-fold (1.30 log units) above the measured one, and the stated range ends above it.
By their numbers in this assay, from the lowest: compound 1; then compounds 3 and 4 (each within the scatter of the next); then compound 2.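

Taking one methyl off 3,4-dimethylphenyl to leave 4-methylphenyl is far from a minor edit: in this assay it gives a 25-fold lower number from compound 2 to compound 4 (1.40 log units; beyond the scatter) and so shows that this single carbon, ortho to a methyl group, can decide much of the growth inhibition. The same methyl is not harmful on every ring, since compound 1 also carries it, alongside a methoxy group, and the change to 4-methylphenyl gives a 4.4-fold higher number from compound 1 to compound 4 (0.65 log units; beyond the scatter) in the opposite direction; its effect therefore depends on the other group on the ring. Nothing available explains this reversal.

Going by these compounds, it remains open how 4-methoxyphenyl, without the methyl, would compare with compound 1, which would isolate the methyl's effect in that setting. Also open, on these data alone, is whether an ethyl group, a chlorine atom or an amine on this carbon would behave like the methyl.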